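Swapping heptyloxy for phenoxy in a flat series

The source may hold more compounds than are shown below. What is called first, only, known or untested is meant among the compounds shown, and "the series" means these compounds.

Among the measured compounds shown here, in a functional assay on brain (Rattus norvegicus, strain Wistar) for inhibition (a higher number here means a weaker inhibitor, a lower number a stronger inhibitor), three compounds sharing one core have numbers so far. Compound 1 `CCCc1ccc(-c2c(C)[nH]c(=O)n2C2CCCCC2)cc1` gives 13900 nM with propyl on an aromatic carbon. Compound 2 `CCCCCCOc1ccc(-c2c(C)[nH]c(=O)n2C2CCCCC2)cc1` gives 8500 nM with hexyloxy there. Compound 3 `CCCCCCCOc1ccc(-c2c(C)[nH]c(=O)n2C2CCCCC2)cc1` gives 11600 nM with heptyloxy, and that value lies within the scatter of both others, so the three cannot be ranked.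

Compound 4 `Cc1[nH]c(=O)n(C2CCCCC2)c1-c1ccc(Oc2ccccc2)cc1` awaits measurement. It has phenyl in place of heptyl on an oxygen on an aromatic ring. The closest evidence comes from changes to the chain: a 1.4-fold higher number from compound 2 to compound 3 (0.14 log units; within the scatter) stayed within the scatter, as did a 1.6-fold lower number from compound 1 to compound 2 (0.21 log units; within the scatter) and a 1.2-fold lower number from compound 1 to compound 3 (0.08 log units; within the scatter) in the same way. None of these steps puts a ring on that oxygen, so the evidence is indirect and the range must stay wide. The expected change is small, no larger than the scatter, at a 1.2-fold lower number from compound 3 to compound 4 (0.06 log units; within the scatter) in this assay as an estimate. In this assay the estimate for compound 4 is 10000 nM with an expected range of 4000 nM to 30000 nM.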

Compound 4, half-maximal inhibitory concentration: 7900 nM
Beside the measured number, compound 4's estimate is 1.3-fold (0.10 log units) above it, within the range that was stated.
By their numbers in this assay, from the lowest: compounds 4, 2, 3 and 1 (each within the scatter of the next).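

In this assay, among the compounds shown here, the new result shows that the oxygen on an aromatic ring can carry a ring as well as a chain, a kind of group the earlier compounds did not include. The three steps are a 1.5-fold lower number from compound 3 to compound 4 (0.17 log units; within the scatter), a 1.1-fold lower number from compound 2 to compound 4 (0.03 log units; within the scatter) and a 1.8-fold lower number from compound 1 to compound 4 (0.25 log units; within the scatter), and all three lie within the scatter. Among these four compounds, then, neither exchanging heptyl or hexyl for phenyl on that oxygen nor exchanging propyl for phenoxy on the aromatic carbon gives a change that can be told from the scatter, and no supporting evidence bears on this result.

As far as these compounds go, it remains open whether a phenyl ring carrying an amine or a carboxylic acid at this position would give a step beyond the scatter. From the compounds shown here alone, it is also open whether any change elsewhere on the shared core would do so.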